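This account rests on a few compounds, and the source may have more. Where it says the series, first, only, none or still open, it means among the compounds named here.

Within the data shown here, compound 3 `Nc1nc(NC2CCCCC2)cc(-c2cc(N3C[C@H](O)[C@@H](O)C3)ccc2O)n1` gives 2000 nM in a functional assay on EJ cells (Homo sapiens) for cytotoxicity, with a stated time of 48 h (on this read-out lower numbers stand for stronger inhibition of growth and higher numbers for weaker inhibition of growth), the highest of the three numbers known. Compound 1 `CCc1cc(-c2cc(N3C[C@H](O)[C@@H](O)C3)ccc2O)nc(N)n1` gives 1500 nM, and compound 2 `Nc1nc(-c2cc(N3C[C@H](O)[C@@H](O)C3)ccc2O)cc(C2CCCC2)n1` gives 900 nM. The step of a 1.3-fold higher number from compound 1 to compound 3 (0.12 log units; within the scatter) stays within the scatter, while a 2.2-fold higher number from compound 2 to compound 3 (0.35 log units; beyond the scatter) is modest but beyond it. Compound 4 `Nc1nc(-c2cc(N3C[C@H](O)[C@@H](O)C3)ccc2O)cc(C2CCCNC2)n1` differs from compound 3 by piperidin-3-yl in place of cyclohexylamino on an aromatic carbon. Among the measured compounds shown here, no measured step swaps these two groups directly. The closest guide is a 2.2-fold higher number from compound 2 to compound 3 (0.35 log units; beyond the scatter), where a cyclopentyl group gave the lower number than cyclohexylamino, and a 1.3-fold higher number from compound 1 to compound 3 (0.12 log units; within the scatter) shows the ethyl group sitting within the scatter of cyclohexylamino. A modest gain at most is therefore expected for compound 4, with the expected step being a 1.8-fold lower number from compound 3 to compound 4 (0.26 log units; within the scatter). Compound 4 is estimated at 1100 nM, in the range from 400 nM to 3000 nM.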

Compound 4, concentration for 50% growth inhibition: > 10000 nM
Compound 4: no number, only a limit; the forecaster's own chance of this, stated with the estimate: 5%; middle value at least 9.0-fold (0.95 log units) away from the limit.
By their numbers in this assay, from the lowest: compounds 2, 1 and 3 (each within the scatter of the next, the first and the last beyond it). At a limit, above all of these: compound 4.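

In this assay compound 4 gives > 10000 nM, which is a limit and not a number. At this aromatic carbon, piperidin-3-yl gives far weaker inhibition of growth than the earlier groups: an at least 5.0-fold higher number from compound 3 to compound 4 (0.69 log units; beyond the scatter), an at least 6.6-fold higher number from compound 1 to compound 4 (0.82 log units; beyond the scatter) and an at least 11-fold higher number from compound 2 to compound 4 (1.04 log units; beyond the scatter). The position is therefore not indifferent to the group it carries, and a ring with a hetero atom brings the largest change seen here.

As far as these compounds go, what remains open is whether the ring nitrogen or some other difference accounts for this. A plain cyclohexyl group, or a piperidine with an acetyl on its nitrogen, would help separate these possibilities.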